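From a Saturated Ring to a Cyanophenyl Amide

The compounds below may be only part of what the source reports. "The series", "measured", "known", "first", "only" and "open" are said of these compounds alone.

Three compounds share one core, each carrying a different group on the carbonyl carbon of the amide. Compound 1 `O=C(C1CCC(F)(F)CC1)N1CCc2nc(C#Cc3ccccc3)sc2C1` bears a 4,4-difluorocyclohexyl group, compound 2 `CC1CCCC(C(=O)N2CCc3nc(C#Cc4ccccc4)sc3C2)C1` a 3-methylcyclohexyl group, and compound 3 `O=C(C1CCOCC1)N1CCc2nc(C#Cc3ccccc3)sc2C1` an oxan-4-yl group. In an assay on HEK293 cells for negative allosteric modulation of metabotropic glutamate receptor 5 (Homo sapiens), read by FLIPR, with a stated time of 1 h (a lower number here means a stronger inhibitor, a higher number a weaker inhibitor), compound 1 reaches only the limit of the assay, at > 10000 nM. In this assay compound 2 likewise stops at the limit, with > 10000 nM. For compound 3 in this assay the result is again only a limit, > 10000 nM. All three values rest at the limit of > 10000 nM in this assay, at which 3 of the 3 values shown sit, so compound 3 cannot be placed above or below its neighbours; the steps a step that the two limits leave unreadable from compound 1 to compound 2, a step that the two limits leave unreadable from compound 1 to compound 3 and a step that the two limits leave unreadable from compound 2 to compound 3 are all unreadable.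

Compound 4 `N#Cc1cccc(C(=O)N2CCc3nc(C#Cc4ccccc4)sc3C2)c1` is not yet measured. It differs from compound 3 by 3-cyanophenyl in place of oxan-4-yl on a carbonyl carbon. Going by the values given here, none of the measured steps can say how such a change acts, since every one of them is hidden by the limit. The expectation for an at least 3.3-fold lower number from compound 3 to compound 4 (0.52 log units; beyond the scatter) is therefore an open guess rather than a reading of a trend. For compound 4 in this assay the estimate is 3000 nM, with a range from 300 nM to 30000 nM.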

Compound 4, half-maximal inhibitory concentration: > 10000 nM
Compound 4: a limit, no number; the forecaster's own chance of this, stated with the estimate: 50%; middle value at least 3.3-fold (0.52 log units) from the limit.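

In this assay compound 4 also gives only a limit, > 10000 nM, and no number. None of the steps from compound 1, compound 2 or compound 3 to compound 4 can be read, because all the values rest at the same limit: the limit of > 10000 nM in this assay, at which 4 of the 4 values shown sit.

The compounds shown leave open whether any group on the carbonyl carbon of the shared core can give a measurable inhibition, and how the four compounds rank against each other.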